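From Fluoro to Methoxy on a Nucleoside Core

The source may hold more compounds than are shown below. What is called first, only, known or untested is meant among the compounds shown, and "the series" means these compounds.

Compound 1 `[N-]=[N+]=N[C@H]1C[C@H](n2cnc3c(N)nc(F)nc32)O[C@@H]1CO` is the only one of the three measured compounds that gives a number in an ADME assay on Vero cells (Chlorocebus sabaeus) for cytotoxicity, with a stated time of 5 days; on this read-out lower numbers stand for stronger inhibition and higher numbers for weaker inhibition: compound 1 gives 34400 nM. Compound 2 `C#CCNc1nc(N)nc2c1ncn2[C@H]1C[C@H](N=[N+]=[N-])[C@@H](CO)O1` gives only a limit of the assay in this assay, namely > 100000 nM. Compound 3 `CN(C)c1nc(Cl)nc2c1ncn2[C@H]1C[C@H](N=[N+]=[N-])[C@@H](CO)O1` likewise gives only a limit, > 100000 nM. Among the compounds with values here, compound 1 therefore stands as the single measured value, while the limit of > 100000 nM in this assay, at which 2 of the 3 values shown sit, holds the other two. Compound 4 `COc1nc(N)c2ncn([C@H]3C[C@H](N=[N+]=[N-])[C@@H](CO)O3)c2n1` differs from compound 1 by methoxy in place of fluoro on an aromatic carbon. Within the data shown here, no measured step between two compounds is at hand, so the expected step of a 1.5-fold higher number from compound 1 to compound 4 (0.16 log units; within the scatter) is estimated as small, toward weaker inhibition, and within the scatter. Compound 4 is expected to give about 50000 nM in this assay, between 15000 nM and 150000 nM.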

Compound 4, half-maximal inhibitory concentration: > 100000 nM
Compound 4 gave a limit, no number (the forecaster's own chance of this, stated with the estimate: 40%); at least 2.0-fold (0.30 log units) between middle value and limit.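

Fluoro to methoxy on the aromatic carbon between two ring nitrogen atoms is the first single change that can be read in this assay, and it gives an at least 2.9-fold higher number from compound 1 to compound 4 (0.46 log units; beyond the scatter). At this position, then, methoxy moves the compound toward weaker inhibition of the cells, well clear of the usual scatter. Compound 4 gives a limit and not a number, so the step has no upper end, and most of the series sits at that same ceiling: the limit of > 100000 nM in this assay, at which 3 of the 4 values shown sit.

From the compounds shown here alone, the true size of the step stays open. So does how an amine or an ethoxy group at this position would compare with fluoro.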